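Swapping the Amide Phenyl for a Methoxybenzyl Group

A few compounds are considered here, and "the series" means these few. Any claim that something is new, unique, unknown or untested is made for them only; others in the source may bear on it.

Of the compounds shown here, three sharing one core have been tested in a functional assay on A549 cells (Homo sapiens) for antiproliferative activity, read by CCK-8 assay, with a stated time of 48 h; on this read-out higher numbers stand for weaker inhibition and lower numbers for stronger inhibition. Compound 1 `O=C(Nc1ccccc1)c1cc(Oc2ccc(/C=C/c3ccccn3)cc2)ccn1` gives 19100 nM in this assay. Compound 2 `O=C(Nc1ccc(Cl)cc1)c1cc(Oc2ccc(/C=C/c3ccccn3)cc2)ccn1`, which carries a chloro group, gives 16200 nM. Compound 3 `O=C(Nc1ccccc1)c1cc(Oc2ccc(/C=C/c3ccncc3)cc2)ccn1` gives 79700 nM, the highest of the three numbers and therefore the weakest inhibition among them; its nearest neighbour is compound 1, and the step of a 4.2-fold higher number from compound 1 to compound 3 (0.62 log units; beyond the scatter) lies beyond the scatter, as does its gap to compound 2.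

Compound 4 `COc1ccc(CNC(=O)c2cc(Oc3ccc(/C=C/c4ccncc4)cc3)ccn2)cc1` has not yet been measured. Compared with compound 3 its structure shows (4-methoxybenzyl in place of phenyl on an amide-type nitrogen). Of the two measured steps, only a 1.2-fold lower number from compound 1 to compound 2 (0.07 log units; within the scatter) alters the group on the amide nitrogen, and that step stayed within the scatter. The other step, a 4.2-fold higher number from compound 1 to compound 3 (0.62 log units; beyond the scatter), concerns the pyridyl ring rather than the amide nitrogen and says nothing about the present change. Going by the values given here, no measured pair shows a phenyl replaced by a benzyl-type group on that nitrogen, so the direction remains open. The expectation for compound 4 is a step of a 1.3-fold lower number from compound 3 to compound 4 (0.12 log units; within the scatter), not clearly beyond the scatter. Compound 4 is therefore estimated at 60000 nM, with a range from 15000 nM to 200000 nM.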

Compound 4, half-maximal inhibitory concentration: 19300 nM
The estimate for compound 4 lay 3.1-fold (0.49 log units) above the measured number, within the range that was stated.
By their numbers in this assay, from the lowest: compounds 2, 1 and 4 (each within the scatter of the next); then compound 3.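

In this assay, 4-methoxybenzyl in place of phenyl on the amide-type nitrogen gives a 4.1-fold lower number from compound 3 to compound 4 (0.62 log units; beyond the scatter), so the group on this nitrogen can move the number beyond the scatter and towards stronger inhibition, whereas the earlier change on the anilide ring, a 1.2-fold lower number from compound 1 to compound 2 (0.07 log units; within the scatter), did not. This step changes two things at once, since the entering group brings both a benzyl carbon and a methoxy group, and the result cannot be divided between them. Nothing available explains why this change lowers the number.

From the compounds shown here alone, it remains open whether a plain benzyl group, without the methoxy, or a 4-methoxyphenyl group, without the benzyl carbon, would produce the same step. Going by these compounds alone, also open are whether a longer chain such as 2-phenylethyl would lower the number further, and whether 4-methoxybenzyl would have a similar effect on the pyridin-2-yl compounds, since this step was seen only with the pyridin-4-yl group.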